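Removing the aminomethyl end from compound 3

A few compounds are considered here, and "the series" means these few. Any claim that something is new, unique, unknown or untested is made for them only; others in the source may bear on it.

compound 1 `CN(C(=O)CNC(=O)CN)c1ccc([N+](=O)[O-])cc1C(=O)c1ccccc1` gives 2.94 mg/kg
compound 2 `CC(=O)NCC(=O)N(C)c1ccc(Cl)cc1C(=O)c1ccccc1Cl` gives 58 mg/kg
compound 3 `CC(NC(=O)CN)C(=O)N(C)c1ccc(Cl)cc1C(=O)c1ccccc1Cl` gives 8.5 mg/kg

In a functional assay on the whole organism with Mus musculus as the target, in the rotarod test (a higher number here means that more compound is needed for the effect, a lower number that less compound is needed), compound 3 sits in the middle of the three numbers, with compound 1 lower and compound 2 higher. Compound 4 `CC(C)C(=O)NCC(=O)N(C)c1ccc(Cl)cc1C(=O)c1ccccc1Cl` differs from compound 3 in one place: ((isopropylcarbonyl)amino)methyl in place of 1-(((aminomethyl)carbonyl)amino)ethyl on a carbonyl carbon. In this change, ((isopropylcarbonyl)amino)methyl replaces 1-(((aminomethyl)carbonyl)amino)ethyl on a carbonyl carbon.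

Within the data shown here, one measured step bears on this: a 6.8-fold lower number from compound 2 to compound 3 (0.83 log units; beyond the scatter). That step brought in the group that compound 4 now gives up, in place of acetamidomethyl. Like compound 2 at 58 mg/kg, compound 4 has no aminomethyl end on this chain, so a step of similar size in the opposite direction is expected. Among the measured compounds shown here, no measured compound shows what the isopropylcarbonyl group does here, so the range stays wide. The expected change is a 4.7-fold higher number from compound 3 to compound 4 (0.67 log units; beyond the scatter). For compound 4 the estimated value is 40 mg/kg, with an expected range of 14 mg/kg to 110 mg/kg.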

Compound 4, dose for half-maximal effect: > 100 mg/kg
Compound 4 was reported as a limit (the forecaster's own chance of this, stated with the estimate: 15%); at least 2.5-fold (0.39 log units) between middle value and limit.
By their numbers in this assay, from the lowest: compound 1; then compound 3; then compound 2. At a limit, above all of these: compound 4.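

In this assay compound 4 gives > 100 mg/kg as a limit of the assay, not a number. Changing the chain on this carbonyl carbon to ((isopropylcarbonyl)amino)methyl brings an at least 11-fold higher number from compound 3 to compound 4 (1.07 log units; beyond the scatter) and shows that, among compound 2, compound 3 and compound 4, only the chain with the aminomethyl end gives a low number; the isopropylcarbonyl end does not make up for its loss. Isopropyl in place of methyl brings an at least 1.7-fold higher number from compound 2 to compound 4 (0.23 log units; that floor lies within the scatter) and leaves compound 2 and compound 4 without an order, and both new steps are floors, not full sizes: the limit of > 100 mg/kg in this assay, at which 1 of the 4 values shown sits.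

Compound 3 also carries a branching methyl on its chain, so the compounds shown do not separate that methyl from the aminomethyl end. They also leave open how a longer chain ending in an amine, or a carboxylic acid at that end, would behave at this position.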